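Expected Shift in Cell Inhibition from Compound 2 to Compound 3

The source may report more compounds than this note shows. Statements on the series, on what has been measured and on what is new or still open speak of the compounds shown alone.

Compound 2 `O=C(/C=C/c1cn(-c2ccc(Cl)cc2)c2ccccc12)CC(=O)C(=O)O`: 27000 nM in a functional assay on MOLT-4 cells (Homo sapiens) for inhibition, read by MTT assay, with a stated time of 48 h; a higher number here means a weaker inhibitor, a lower number a stronger inhibitor

Among the measured compounds shown here, compound 2 holds the only number in this set. For the measured compounds named here, compound 1 `CCOC(=O)C(=O)CC(=O)/C=C/c1cn(-c2ccc(Cl)cc2)c2ccccc12` gives "not determined" (no result reported) in this assay, so nothing can be said of how it compares, and there is no step between two measured compounds to show how much any change of structure moves the numbers. Compound 3 `CN(C)C(=O)Cn1cc(/C=C/C(=O)CC(=O)C(=O)O)c2ccccc21` is the unmeasured compound that follows compound 2; the change is (dimethylcarbamoyl)methyl in place of 4-chlorophenyl on an aromatic nitrogen. Going by the values given here, with no measured step to rest on, the size of the step in this assay can only be guessed. The expectation is a moderate weakening, a 1.7-fold higher number from compound 2 to compound 3 (0.22 log units; within the scatter), which may or may not exceed the usual scatter. Compound 3 is accordingly expected to show 45000 nM, within a range from 12000 nM to 170000 nM, with a fair chance that only a limit is reported.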

Compound 3, half-maximal inhibitory concentration: > 40000 nM
Compound 3: no number, only a limit (the forecaster's own chance of this, stated with the estimate: 30%); the middle value lies beyond the limit too.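

In this assay, among the compounds shown here, the first change that can be read on the aromatic nitrogen, (dimethylcarbamoyl)methyl in place of 4-chlorophenyl, gives an at least 1.4-fold higher number from compound 2 to compound 3 (0.17 log units; that floor lies within the scatter). Compound 3 gives > 40000 nM, which is a limit of the assay and not a number. Because this is a limit, the step is only a floor: it shows that this change brought no stronger inhibition, but not how much weaker compound 3 is, if it is weaker at all: the limit of > 40000 nM in this assay, at which 1 of the 3 values shown sits.

The compounds shown leave open whether a plain phenyl or a small methyl on the same aromatic nitrogen would keep the inhibition seen with compound 2. They also leave open whether a chain ending in an amine, rather than the dimethyl amide, would behave differently at this place.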